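Benzoxazole for benzisoxazole on a piperazine amine

The source may hold more compounds than are shown below. What is called first, only, known or untested is meant among the compounds shown, and "the series" means these compounds.

Compound 1 `COc1ccccc1N1CCN(CCCCCC(=O)NC2CCCc3c(OC)cccc32)CC1` gives 20 nM in an assay on HEK293 cells for displacement of a labelled ligand from 5-hydroxytryptamine receptor 7 (Rattus norvegicus); on this read-out higher numbers stand for weaker inhibition and lower numbers for stronger inhibition.
Compound 2 `COc1ccccc1N1CCN(CCCC(=O)NC2CCCc3cccc(OC)c32)CC1` gives 154 nM in this assay.
Compound 3 `O=C(CCCCCN1CCN(c2noc3ccccc23)CC1)NC1CCCc2ccccc21` gives 125 nM in this assay.

Among the three numbers, compound 3 holds the second highest. Its nearest neighbour is compound 2, whose value lies within the scatter of that of compound 3, so the two cannot be told apart. Compound 1, by contrast, gives a clearly lower number than compound 3, a gap that lies beyond the scatter.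

Compound 4 `COc1ccc2oc(N3CCN(CCCCCC(=O)NC4CCCc5ccccc54)CC3)nc2c1` has not yet been measured. It differs from compound 3 in one place: a group of 11 heavy atoms (8 carbon, 1 nitrogen, 2 oxygen; one five-membered aromatic ring with 2 hetero atoms, one six-membered aromatic ring of carbon only) in place of a group of 9 heavy atoms (7 carbon, 1 nitrogen, 1 oxygen; one five-membered aromatic ring with 2 hetero atoms, one six-membered aromatic ring of carbon only), on an amine nitrogen in a ring. Going by the values given here, no pair of measured compounds differs only at this position, so there is no measured step to lean on. The change keeps the same bicyclic aromatic pattern on the piperazine nitrogen and adds one methoxy group. Compound 4 is therefore expected to land close to compound 3, with at most a modest shift toward a lower number, giving an estimated step of a 1.6-fold lower number from compound 3 to compound 4 (0.19 log units; within the scatter). The estimate for compound 4 in this assay is 80 nM, within a range from 25 nM to 300 nM.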

Compound 4, inhibition constant: 704 nM
Beside the measured number, compound 4's estimate is 8.8-fold (0.94 log units) below it; the measured number lies above the stated range.
By their numbers in this assay, from the lowest: compound 1; then compounds 3 and 2 (each within the scatter of the next); then compound 4.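

In this assay, going by these compounds alone, placing 5-methoxy-1,3-benzoxazol-2-yl on the ring amine nitrogen in place of the group carried by compound 3 gives a 5.6-fold higher number from compound 3 to compound 4 (0.75 log units; beyond the scatter), the first measured step at this position. The number moves toward weaker inhibition, so this position does not treat the two groups as interchangeable, although each has one five-membered aromatic ring with 2 hetero atoms and one six-membered aromatic ring of carbon only. Nothing measured here accounts for the size or direction of this step.

The step combines a different arrangement of the bicyclic group with an added methoxy group, and this single pair cannot divide the effect between them. From the compounds shown here alone, a plain 1,3-benzoxazol-2-yl, with hydrogen in place of the methoxy group, would show how much of the step belongs to each, and that remains open.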